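Removing the acetyl from a tetrahydroquinoline amide

This account rests on a few compounds, and the source may have more. Where it says the series, first, only, none or still open, it means among the compounds named here.

Compound 1 `CC(=O)N1c2ccccc2CCC1C(=O)Nc1cc(C(F)(F)F)cc(C(F)(F)F)c1` is a ring-fused amide whose ring nitrogen carries an acetyl group. In a functional assay on HCT-15 cells (Homo sapiens) for cytotoxicity, read by sulforhodamine B assay, with a stated time of 72 h (a higher number here means a weaker inhibitor of growth, a lower number a stronger inhibitor of growth), compound 1 gives > 70000 nM, which is a limit of the measurement rather than a number. It therefore stands at the weak end of what was recorded, as the limit of > 70000 nM in this assay, at which 1 of the 2 values shown sits, shows. Among the compounds with values here, the only other measured compound, compound 2 `COc1ccc(NC(=O)C2CCc3ccccc3N2)cc1`, carries a free ring nitrogen and a methoxyphenyl amide and gives 50200 nM in this assay, a weak but countable value.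

Compound 3 `O=C(Nc1cc(C(F)(F)F)cc(C(F)(F)F)c1)C1CCc2ccccc2N1` differs from compound 1 in one place: hydrogen in place of acetyl on a nitrogen on an aromatic ring in a ring. Within the data shown here, no measured pair shows this exact change, so its size is unknown. Compound 2 shows that a free ring nitrogen can give a value inside the range of this assay, which is the only pointer available. The step from compound 1 to compound 3 is expected to be small, likely no more than the scatter, and might bring the value into the countable range, as an at least 1.5-fold lower number from compound 1 to compound 3 (0.19 log units; that floor lies within the scatter) expresses. Compound 3 is estimated at 45000 nM, with a range from 10000 nM to 150000 nM.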

Compound 3, concentration for 50% growth inhibition: 8700 nM
For compound 3 the middle estimate is 5.2-fold (0.71 log units) above the measured one; measured number below the stated range.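

Within the data shown here, replacing the acetyl with hydrogen on the ring nitrogen gives the first readable change at this position: in this assay it produces an at least 8.0-fold lower number from compound 1 to compound 3 (0.90 log units; beyond the scatter). Compound 1 has a limit and not a number, so this size is only a floor and the true step could be larger: the limit of > 70000 nM in this assay, at which 1 of the 3 values shown sits.

The earlier compounds shown here offered no pair differing in one place, so they could only suggest that a free ring nitrogen was compatible with a countable value; this pair shows that, with the rest of the molecule held the same, the group on this nitrogen alone moves the number beyond the scatter.

As far as these compounds go, the pair does not say whether the acetyl as a whole or its carbonyl is what matters, and it remains open whether a methyl group or a longer chain such as propyl on the same nitrogen would behave like the acetyl or like the hydrogen. From the compounds shown here alone, it also remains open whether the same step would hold for the methoxyphenyl amide of compound 2, as this one pair speaks only for the amide it carries.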